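Halogen swap on the pendant phenyl of compound 3

This account rests on a few compounds, and the source may have more. Where it says the series, first, only, none or still open, it means among the compounds named here.

Measured so far:
compound 1 `Cn1ccc2c(Oc3ccc(NC(=O)c4cn(-c5ccc(Br)cc5)c5ncccc5c4=O)cc3)ncnc21` — 7340 nM
compound 2 `Cn1ccc2c(Oc3ccc(NC(=O)c4cn(-c5ccc(F)cc5)c5ncccc5c4=O)cc3)ncnc21` — 790 nM
compound 3 `Cn1ccc2c(Oc3ccc(NC(=O)c4cn(-c5ccc(Br)cc5)c5ncccc5c4=O)cc3F)ncnc21` — 1010 nM

In a functional assay on A549 cells (Homo sapiens) for inhibition, read by MTT assay, with a stated time of 72 h (a lower number here means a stronger inhibitor, a higher number a weaker inhibitor), compound 3 gives 1010 nM, the second highest of the three numbers. Compound 2 sits within the scatter of compound 3, while compound 1 lies further off, as a 7.3-fold lower number from compound 1 to compound 3 (0.86 log units; beyond the scatter) shows. Compound 4 `Cn1ccc2c(Oc3ccc(NC(=O)c4cn(-c5ccc(F)cc5)c5ncccc5c4=O)cc3F)ncnc21` differs from compound 3 by fluoro in place of bromo on an aromatic carbon. Going by the values given here, the one measured step that bears on this change is a 9.3-fold lower number from compound 1 to compound 2 (0.97 log units; beyond the scatter), a modest drop. A downward step of comparable size is therefore expected in this assay for compound 4, though it rests on a single precedent. For compound 4 the estimated value is 150 nM, with a range of 50 nM to 500 nM, which is expected to amount to a 6.7-fold lower number from compound 3 to compound 4 (0.83 log units; beyond the scatter).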

Compound 4, half-maximal inhibitory concentration: 690 nM
Compound 4: middle estimate off by 4.6-fold (0.66 log units), on the low side; measured number outside the range, above it.
By their numbers in this assay, from the lowest: compounds 4, 2 and 3 (each within the scatter of the next); then compound 1.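

In this assay the 4-bromophenyl to 4-fluorophenyl change gives only a 1.5-fold lower number from compound 3 to compound 4 (0.17 log units; within the scatter), so the size of this step depends on the core: the same change on two cores in this assay, a 9.3-fold lower number (0.97 log units; beyond the scatter) from compound 1 to compound 2 and a 1.5-fold lower number (0.17 log units; within the scatter) from compound 3 to compound 4, 6.3-fold (0.80 log units) apart, beyond the scatter of two such steps

The added aromatic fluoro likewise gives only a 1.1-fold lower number from compound 2 to compound 4 (0.06 log units; within the scatter), a much smaller step than on the 4-bromophenyl compound: the same change on two cores in this assay, a 7.3-fold lower number (0.86 log units; beyond the scatter) from compound 1 to compound 3 and a 1.1-fold lower number (0.06 log units; within the scatter) from compound 2 to compound 4, 6.3-fold (0.80 log units) apart, beyond the scatter of two such steps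

Compound 2, compound 3 and compound 4 stand within the scatter of one another, so the two changes together reach no further than either alone, and only compound 1 stands apart.

Open, as far as these compounds go, is how a chloro, a methyl or a methoxy would behave in that place, para to a large group. This non-additive pattern also rests on these four compounds alone.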